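Swapping a diethylamino end for isopropyl on the chain

The source may hold more compounds than are shown below. What is called first, only, known or untested is meant among the compounds shown, and "the series" means these compounds.

In an ADME assay on BaF3 cells (Mus musculus) for cytotoxicity, read by CellTiter-Glo and CCK-8 assay, with a stated time of 72 h (on this read-out higher numbers stand for weaker inhibition of growth and lower numbers for stronger inhibition of growth), compound 1 (`C=CC(=O)NCc1ccc(C(=O)Nc2ccc(C)c(Nc3nccc(-c4cccnc4)n3)c2)cc1`) gives > 10000 nM, which is a limit of the assay and not a number. Among the compounds with values here, compound 2 (`C=CC(=O)N(CCN(CC)CC)Cc1ccc(C(=O)Nc2ccc(C)c(Nc3nccc(-c4cccnc4)n3)c2)cc1`) gives 5450 nM, the only actual number so far. Compound 3 (`C=CC(=O)N(CCC(C)C)Cc1ccc(C(=O)Nc2ccc(C)c(Nc3nccc(-c4cccnc4)n3)c2)cc1`) has isopropyl in place of diethylamino on a saturated chain carbon, two bonds along the chain from an amide-type nitrogen. Within the data shown here, the only measured step is an at least 1.8-fold lower number from compound 1 to compound 2 (0.26 log units; that floor lies within the scatter). It put 2-(diethylamino)ethyl in place of hydrogen on that same amide-type nitrogen, and it offers no size beyond the scatter to carry forward. No clear shift is therefore expected in this assay, and the estimated change is a 1.1-fold lower number from compound 2 to compound 3 (0.04 log units; within the scatter). For compound 3 the estimated value is 5000 nM, with an expected range from 2000 nM to 10000 nM.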

Compound 3, concentration for 50% growth inhibition: 5620 nM
Compound 3: the middle estimate sits 1.1-fold (0.05 log units) below what was measured, and the stated range covers the measured number.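

On this chain, the diethylamino end with its nitrogen can be exchanged for the all-carbon isopropyl end without a readable difference in this assay, giving a 1.0-fold higher number from compound 2 to compound 3 (0.01 log units; within the scatter). Compound 2 and compound 3 therefore cannot be told apart here, so the nitrogen of the diethylamino group is not shown to matter in this read-out. The all-carbon chain also gives an at least 1.7-fold lower number from compound 1 to compound 3 (0.25 log units; that floor lies within the scatter), so neither chain on the amide-type nitrogen is shown to separate from the unsubstituted compound 1, and the true size of that gap stays unknown because compound 1 sits at a limit and not at a number: the limit of > 10000 nM in this assay, at which 1 of the 3 values shown sits.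

From the compounds shown here alone, whether a carboxylic acid at the chain end would give a number outside the scatter remains open. So does whether a longer chain, such as octyl, on the amide-type nitrogen would do so.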